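The compounds below may be only part of what the source reports. "The series", "measured", "known", "first", "only" and "open" are said of these compounds alone.

Of the compounds shown here, three sharing one core have been tested in a functional assay on the whole organism for antagonist activity, with Mus musculus as the target; on this read-out lower numbers stand for an effect already at smaller amounts and higher numbers for an effect only at larger amounts of compound. Compound 1 `COc1cc(N)c(Cl)cc1NC(=O)C1CCN(CC2CCCCC2)CC1` carries cyclohexyl on a saturated chain carbon bound to an amine nitrogen in a ring and in this assay gives 2.9 mg/kg. Compound 3 `COc1cc(N)c(Cl)cc1NC(=O)C1CCN(Cc2cccc(C)c2)CC1`, with 3-methylphenyl on a saturated chain carbon bound to an amine nitrogen in a ring, gives 2.4 mg/kg. Compound 2 `COc1cc(N)c(Cl)cc1NC(=O)C1CCN(Cc2ccccc2Cl)CC1`, bearing 2-chlorophenyl there, reached only a limit of this assay, > 4 mg/kg. Its standing is thus known only as a floor (the limit of > 4 mg/kg in this assay, at which 1 of the 3 values shown sits).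

Compound 4 `CCCCCN1CCC(C(=O)Nc2cc(Cl)c(N)cc2OC)CC1` differs from compound 2 by butyl in place of 2-chlorophenyl on a saturated chain carbon bound to an amine nitrogen in a ring. The measured steps touching compound 2 were an at least 1.3-fold higher number from compound 1 to compound 2 (0.13 log units; that floor lies within the scatter) and an at least 1.6-fold lower number from compound 2 to compound 3 (0.22 log units; that floor lies within the scatter), neither beyond the scatter, so no change beyond the scatter is expected in this assay. Compound 4 is expected to give 3.5 mg/kg, within 1.7 mg/kg to 8 mg/kg. That means an expected step of an at least 1.1-fold lower number from compound 2 to compound 4 (0.05 log units; that floor lies within the scatter).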

Compound 4, dose for half-maximal effect: > 10 mg/kg
Compound 4: a limit, no number; the forecaster's own chance of this, stated with the estimate: 35%; at least 2.8-fold (0.45 log units) between middle value and limit.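

In this assay, among these compounds, butyl at this place gives the first changes beyond the scatter: an at least 4.1-fold higher number from compound 3 to compound 4 (0.61 log units; beyond the scatter), and an at least 3.4-fold higher number from compound 1 to compound 4 (0.53 log units; beyond the scatter). Compound 1 with cyclohexyl and compound 3 with 3-methylphenyl lie within the scatter of each other, so both ring groups give lower numbers here than the chain without a ring. The step between compound 2 and compound 4 cannot be read, as both values are limits, so compound 2 cannot be placed in this pattern.

Going by these compounds, whether the ring itself matters or only this chain stays open. An ethyl group or a chain ending in an amine would help to separate the two.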